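Five-membered aromatic rings at the far end of the series

The source may hold more compounds than are shown below. What is called first, only, known or untested is meant among the compounds shown, and "the series" means these compounds.

Compound 1 `Cc1oc(C(=O)O)cc1COc1ccc(-c2ccc(CO)cc2)cc1` gives 3000 nM in an assay on cells for displacement of a labelled ligand from prostaglandin E2 receptor EP4 subtype (Homo sapiens), read by scintillation counting; a higher number here means a weaker inhibitor, a lower number a stronger inhibitor. Compound 2 `Cc1oc(C(=O)O)cc1COc1ccc(-c2ccc(C#N)cc2)cc1` gives 1500 nM in this assay, and the step of a 2.0-fold lower number from compound 1 to compound 2 (0.30 log units; within the scatter) lies within the scatter. Compound 3 `Cc1oc(C(=O)O)cc1COc1ccc(-c2ccoc2)cc1` gives only a limit in this assay, > 10000 nM, so its true number is not known. Compound 3 sits at the limit of > 10000 nM in this assay, at which 1 of the 3 values shown sits. It stands at the weak end of the measured set, since the steps of an at least 3.3-fold higher number from compound 1 to compound 3 (0.52 log units; beyond the scatter) and an at least 6.6-fold higher number from compound 2 to compound 3 (0.82 log units; beyond the scatter) are both beyond the scatter.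

Compound 4 `Cc1oc(C(=O)O)cc1COc1ccc(-c2nnco2)cc1` carries 1,3,4-oxadiazol-2-yl in place of furan-3-yl on an aromatic carbon. Within the data shown here, no measured step exchanges one five-membered aromatic ring for another; the two steps that reach compound 3 show only that the furan-3-yl lands at the limit, and neither tells whether a different five-membered ring recovers what was lost. The step of a number no higher from compound 3 to compound 4 (the limit leaves the size open) is therefore expected to stay within the scatter, with the result again likely to fall at the limit. For compound 4 the estimate in this assay is 10000 nM, in the range 3000 nM to 30000 nM.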

Compound 4, inhibition constant: > 10000 nM
Compound 4 ended at the assay's limit (the forecaster's own chance of this, stated with the estimate: 55%); the middle value lies on the limit itself.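

In this assay compound 4 gives > 10000 nM, which is a limit and not a number. At this position, para to a large group, the result extends what compound 3 showed to a second five-membered aromatic ring: going from 1 to 3 hetero atoms and from 1 to 3 hydrogen-bond acceptors brings no readable value, and the losses against the six-membered aryl groups, an at least 6.6-fold higher number from compound 2 to compound 4 (0.82 log units; beyond the scatter) and an at least 3.3-fold higher number from compound 1 to compound 4 (0.52 log units; beyond the scatter), both lie beyond the scatter. The two five-membered rings cannot be ranked, and the step between compound 3 and compound 4 cannot be read: the limit of > 10000 nM in this assay, at which 2 of the 4 values shown sit.

Going by these compounds, how far either compound lies past the limit remains open. Also open, on these data alone, is whether a nitrile or a hydroxymethyl group carried on the five-membered ring, or an amine there, would bring back a measurable value.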